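Adding a second methyl to compound 2

The compounds below may be only part of what the source reports. "The series", "measured", "known", "first", "only" and "open" are said of these compounds alone.

Measured in an ADME assay on CCRF-CEM cells (Homo sapiens) for cytotoxicity, read by MTT assay, with a stated time of 4 days (a higher number here means that more compound is tolerated, a lower number that less compound is tolerated), for three compounds:
Compound 1 `Cc1cc(C)cc(Cc2cc(Cl)ccc2OCCn2ccc(=O)[nH]c2=O)c1` gives > 200000 nM as a limit
Compound 2 `Cc1cccc(Cc2cc(C)ccc2OCCn2ccc(=O)[nH]c2=O)c1` gives 53000 nM as a number
Compound 3 `Cc1cc(C)cc(C(O)c2cc(Cl)ccc2OCCn2ccc(=O)[nH]c2=O)c1` gives > 20000 nM as a limit

Among the compounds with values here, compound 2 holds the only number here, since the other two values are limits. Compound 4 `Cc1cc(C)cc(Cc2cc(C)ccc2OCCn2ccc(=O)[nH]c2=O)c1` differs from it by methyl in place of hydrogen on an aromatic carbon in which 3-methylbenzyl becomes 3,5-dimethylbenzyl. Within the data shown here, no measured step covers this change. The one available, a step that the two limits leave unreadable from compound 1 to compound 3 (hydroxy in place of hydrogen on a saturated chain carbon), is a different change. Compound 1 carries 3,5-dimethylbenzyl as well and its > 200000 nM is a limit, so a small shift toward more compound tolerated is expected. Expected is a 1.3-fold higher number from compound 2 to compound 4 (0.12 log units; within the scatter) that would stay within the usual scatter. For compound 4 the estimate is 70000 nM with an expected range from 25000 nM to 200000 nM in this assay here.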

Compound 4, half-maximal cytotoxic concentration in the CCRF-CEM assay: 66000 nM
For compound 4 the middle estimate is 1.1-fold (0.03 log units) above the measured one; the measured number falls inside the stated range.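

In the CCRF-CEM assay, going from 3-methylbenzyl to 3,5-dimethylbenzyl gives a 1.2-fold higher number from compound 2 to compound 4 (0.10 log units; within the scatter). In a physicochemical assay for solubility (a higher number here means a more soluble compound, a lower number a less soluble compound), compound 2 gives 36500 nM and compound 4 gives 44400 nM. In the physicochemical assay the same change gives a 1.2-fold higher number from compound 2 to compound 4 (0.09 log units; within the scatter), so this position takes a second methyl with no readable shift in either assay. In the CCRF-CEM assay, methyl in place of chloro on an aromatic carbon gives an at least 3.0-fold lower number from compound 1 to compound 4 (0.48 log units; beyond the scatter), a larger step than the added methyl. Compound 1 holds a limit, not a number: the limit of > 200000 nM in the CCRF-CEM assay, at which 1 of the 4 values shown sits.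

The compounds shown leave open whether an ethyl, a methoxy or an amine at this place would move either read-out.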